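The source may hold more compounds than are shown below. What is called first, only, known or untested is meant among the compounds shown, and "the series" means these compounds.

In a physicochemical assay for solubility, read by HPLC, using the shake flask method, measured as kinetic solubility, with a stated time of 2 h, at pH 7.4 (a lower number here means a less soluble compound, a higher number a more soluble compound), compound 3 `Cc1cc(NCc2c[nH]cn2)n2nc(C)c(-c3ccccc3)c2n1` gives 14600 nM, which is the lowest of the two plain numbers shown; the nearest is compound 1 `Cc1cc(NCc2cccnc2)n2nc(C)c(-c3ccccc3)c2n1`, which in this assay gives 110000 nM. Compound 2 `Cc1cc(NCc2ncc[nH]2)n2nc(C)c(-c3ccccc3)c2n1` is reported only as a limit of this assay, < 5000 nM, and not as a number (the limit of < 5000 nM in this assay, at which 1 of the 3 values shown sits).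

The step to compound 4 `Cc1cc(NCc2cccs2)n2nc(C)c(-c3ccccc3)c2n1` exchanges one ring for another: thiophen-2-yl in place of 1H-imidazol-4-yl on a saturated chain carbon bound to a nitrogen on an aromatic ring. Among the compounds with values here, none of the measured steps is this exact change, but all three touch the same position. The move from pyridin-3-yl to an imidazole gave an at least 22-fold lower number from compound 1 to compound 2 (1.34 log units; beyond the scatter) and a 7.5-fold lower number from compound 1 to compound 3 (0.88 log units; beyond the scatter), and the change between the two imidazoles gave an at least 2.9-fold higher number from compound 2 to compound 3 (0.46 log units; beyond the scatter). Within the data shown here, every swap of the ring at this position so far has shifted the read-out beyond the scatter, so a change beyond the scatter is expected here too. Since thiophen-2-yl carries no hydrogen-bond donor and no ring nitrogen, the expectation is a drop rather than a rise, though of modest size, so that compound 4 is estimated to give 7000 nM in this assay, within a range from 2000 nM to 30000 nM. This expected step, a 2.1-fold lower number from compound 3 to compound 4 (0.32 log units; beyond the scatter), may also land at the limit of this assay.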

Compound 4, solubility: < 5000 nM
Compound 4 gave a limit, no number (the forecaster's own chance of this, stated with the estimate: 35%); middle value at least 1.4-fold (0.14 log units) away from the limit.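

In this assay, thiophen-2-yl on this saturated chain carbon gives an at least 2.9-fold lower number from compound 3 to compound 4 (0.46 log units; beyond the scatter), and set against pyridin-3-yl it gives an at least 22-fold lower number from compound 1 to compound 4 (1.34 log units; beyond the scatter). Among the four compounds, a plain number appears only with pyridin-3-yl and 1H-imidazol-4-yl, so this position now has two rings that give plain numbers and two that do not, and a ring nitrogen alone does not decide which: compound 2, with its 1H-imidazol-2-yl ring, goes against any such rule, while thiophen-2-yl, with sulfur as its only hetero atom and no hydrogen-bond donor, falls in the same group. Compound 4 is reported only as a limit and not as a number, and it is now the second compound to stop there: the limit of < 5000 nM in this assay, at which 2 of the 4 values shown sit.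

From the compounds shown here alone, how far compound 2 and compound 4 lie from that limit stays unknown, and the step between them cannot be read. Also open, going by these compounds, is whether a carboxylic acid or an amine placed on the thiophen-2-yl ring, or a longer chain carrying that ring, would bring the read-out back to a plain number.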